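From benzyloxycarbonyl to 2-methoxybenzyl on the amine

The source may hold more compounds than are shown below. What is called first, only, known or untested is meant among the compounds shown, and "the series" means these compounds.

Compound 1, `CCCCCN(CCCCC)C(=O)[C@H]1CCN(C(=O)N(c2ccccc2)c2cccc(Cl)c2)[C@H](C(=O)NCCN(CC(N)=O)C(=O)OCc2ccccc2)C1`: 1.8 nM
Compound 2, `CCCCCN(CCCCC)C(=O)[C@H]1CCN(C(=O)N(c2ccccc2)c2ccccc2)[C@H](C(=O)NCCNCC(N)=O)C1`: 13 nM

Both were tested in an assay on CHO cells for binding affinity to Substance-P receptor (Homo sapiens); on this read-out lower numbers stand for stronger inhibition and higher numbers for weaker inhibition. Compound 1 gives 1.8 nM, the lowest of the two numbers, while compound 2 gives 13 nM, a higher number that lies beyond the usual scatter. Compound 3, `CCCCCN(CCCCC)C(=O)[C@H]1CCN(C(=O)N(c2ccccc2)c2cccc(Cl)c2)[C@H](C(=O)NCCN(CC(N)=O)Cc2ccccc2OC)C1`, has not yet been measured. It differs from compound 1 in one place: 2-methoxybenzyl in place of benzyloxycarbonyl on an amine nitrogen. Among the measured compounds shown here, no measured pair shows this change on its own, so its effect is uncertain. A modest weakening is expected, with an estimated step in this assay of a 2.2-fold higher number from compound 1 to compound 3 (0.35 log units; beyond the scatter). Compound 3 is expected to give about 4 nM, within a range from 1 nM to 16 nM.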

Compound 3, half-maximal inhibitory concentration: 3.8 nM
Estimate against measurement, compound 3: 1.1-fold (0.02 log units) above; low and high end bracket the measured number.
By their numbers in this assay, from the lowest: compound 1; then compound 3; then compound 2.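

In this assay, the step of a 2.1-fold higher number from compound 1 to compound 3 (0.32 log units; beyond the scatter) is modest, though beyond the usual scatter. This amine nitrogen therefore tolerates losing the carbonyl of benzyloxycarbonyl and gaining a methoxy group on the benzene ring, with compound 3 still at 3.8 nM. Nothing measured here explains the size of this step.

From the compounds shown here alone, because the carbonyl and the methoxy group change together, their separate contributions remain open. A plain benzyl group on this nitrogen would separate them, while compound 2 differs from compound 1 in more than one place and cannot settle the question.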